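Benzyl in place of propyl on the ring amine

The compounds below may be only part of what the source reports. "The series", "measured", "known", "first", "only" and "open" are said of these compounds alone.

Measured compounds in a functional assay on trachea (Cavia porcellus); a higher number here means a weaker inhibitor, a lower number a stronger inhibitor:
- Compound 1, `CO[C@@]12CCN(Cc3ccccc3)C[C@H]1[C@H](c1ccccc1)C(C#N)=C(N)O2`, gives 22600 nM.
- Compound 2, `CO[C@@]12CCN(C)C[C@H]1[C@H](c1ccc(Cl)cc1)C(C#N)=C(N)O2`, gives 10500 nM.
- Compound 3, `CCCN1CC[C@@]2(OC)OC(N)=C(C#N)[C@@H](c3ccc(Cl)cc3)[C@@H]2C1`, gives 30300 nM.

Compound 3 has the highest number of the three in this assay. Its nearest neighbour is compound 1, within the scatter of it, and its furthest is compound 2, which lies beyond the scatter.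

Compound 4 is `CO[C@@]12CCN(Cc3ccccc3)C[C@H]1[C@H](c1ccc(Cl)cc1)C(C#N)=C(N)O2`. It differs from compound 3 by phenyl in place of ethyl on a saturated chain carbon bound to an amine nitrogen in a ring. Going by the values given here, the one measured step at this place is a 2.9-fold higher number from compound 2 to compound 3 (0.46 log units; beyond the scatter), a modest weakening when a larger group sits on the ring nitrogen. Among the compounds with values here, no measured pair shows the benzyl against the propyl directly; compound 1, which carries the benzyl with an unsubstituted phenyl, sits within the scatter of compound 3. Taken together, these point to no step beyond the scatter, with a slight lean to a higher number: the expected step is a 1.1-fold higher number from compound 3 to compound 4 (0.02 log units; within the scatter). Compound 4 is therefore estimated at 32000 nM, in the range 12000 nM to 80000 nM.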

Compound 4, half-maximal inhibitory concentration: 18500 nM
Compound 4: the middle estimate sits 1.7-fold (0.24 log units) above what was measured; the measured number falls inside the stated range.
By their numbers in this assay, from the lowest: compounds 2, 4, 1 and 3 (each within the scatter of the next, the first and the last beyond it).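

In this assay, the change from propyl to benzyl on the ring nitrogen can now be read directly (a 1.6-fold lower number from compound 3 to compound 4 (0.21 log units; within the scatter)). Benzyl also stays within the scatter of the hydrogen-bearing reference, compound 2 (a 1.8-fold higher number from compound 2 to compound 4 (0.25 log units; within the scatter)), whereas propyl moved beyond it (a 2.9-fold higher number from compound 2 to compound 3 (0.46 log units; beyond the scatter)), so the earlier weakening does not carry over to every larger group at this place. Going by these compounds alone, the first reading of chloro in place of hydrogen on an aromatic carbon also stays within the scatter (a 1.2-fold lower number from compound 1 to compound 4 (0.09 log units; within the scatter)), so the chloro has no clear effect in this benzyl pair.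

No evidence is available that explains these steps. As far as these compounds go, whether a longer chain ending in phenyl, or an amine on the phenyl ring of the benzyl, would shift the number beyond the scatter remains open.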